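The source may hold more compounds than are shown below. What is called first, only, known or untested is meant among the compounds shown, and "the series" means these compounds.

Compound 3, `Cc1cc(OC(C)C)cc(C)c1-c1cccc(COc2ccc(OCC(=O)O)c(F)c2)c1`, carries an isopropoxy group on an oxygen on an aromatic ring. In a functional assay on CHO cells for agonist activity at Free fatty acid receptor 1 (Homo sapiens), read by FLIPR and calcium flux (on this read-out lower numbers stand for an effect already at smaller amounts and higher numbers for an effect only at larger amounts of compound), compound 3 gives "not determined" (no result reported), so nothing is known of where it stands. Two relatives of the same core have been measured. Compound 1, `Cc1cc(O)cc(C)c1-c1cccc(COc2ccc(OCC(=O)O)c(F)c2)c1`, has a bare hydroxyl at that oxygen, and compound 2, `COc1cc(C)c(-c2cccc(COc3ccc(OCC(=O)O)c(F)c3)c2)c(C)c1`, has a methyl on it. In this assay compound 1 gives 110 nM, and compound 2 gives 49.7 nM. Among the measured compounds shown here, the single measured step is a 2.2-fold lower number from compound 1 to compound 2 (0.35 log units; beyond the scatter), a modest move toward an effect at smaller amounts. Compound 4, `CCOc1cc(C)c(-c2cccc(COc3ccc(OCC(=O)O)c(F)c3)c2)c(C)c1`, differs from compound 3 only as follows: hydrogen in place of methyl on a saturated chain carbon bound to an oxygen on an aromatic ring and a saturated chain carbon. No measured step covers this exact change, but the one step shown tells that changing what sits on this oxygen shifts the number only modestly, so a small shift at most, in either direction, is expected. Taking compound 2 as the nearest anchor because of 49.7 nM, compound 4 is estimated at 50 nM, with a range from 20 nM to 150 nM.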

Compound 4, half-maximal effective concentration: 65.9 nM
Compound 4: the middle estimate sits 1.3-fold (0.12 log units) below what was measured; low and high end bracket the measured number.
By their numbers in this assay, from the lowest: compounds 2, 4 and 1 (each within the scatter of the next, the first and the last beyond it).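

Going from methoxy to ethoxy on this oxygen gives a 1.3-fold higher number from compound 2 to compound 4 (0.12 log units; within the scatter) in this assay, so one more methyl on the saturated chain carbon leaves the two compounds indistinguishable. Ethyl in place of hydrogen on the oxygen gives a 1.7-fold lower number from compound 1 to compound 4 (0.22 log units; within the scatter), although the smaller methyl gave a step beyond the scatter, a 2.2-fold lower number from compound 1 to compound 2 (0.35 log units; beyond the scatter), so the ethoxy compound cannot be separated from either the hydroxyl or the methoxy compound. Nothing in the data shown offers an explanation for these numbers.

Where the branched isopropoxy group of compound 3 falls remains open. So does how a longer chain such as butoxy, or a chain ending in an amine or a carboxylic acid, would read on this oxygen.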